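The source may report more compounds than this note shows. Statements on the series, on what has been measured and on what is new or still open speak of the compounds shown alone.

In a functional assay for agonist activity at G protein-coupled receptor 88 (Homo sapiens), read by HTRF and cAMP accumulation; on this read-out lower numbers stand for an effect already at smaller amounts and higher numbers for an effect only at larger amounts of compound: compound 1 `CC(C)C[C@H](N)CN(C(=O)[C@@H]1C[C@H]1c1ccccc1)c1ccc(-c2cccnc2)cc1` gives 10000 nM; compound 2 `CC(C)C[C@H](N)CN(C(=O)[C@@H]1C[C@H]1c1ccccc1)c1ccc(-c2cccs2)cc1` gives 1500 nM; compound 3 `Cc1ccccc1-c1ccc(N(C[C@@H](N)CC(C)C)C(=O)[C@@H]2C[C@H]2c2ccccc2)cc1` gives 3400 nM.

Compound 3 stands second highest of the three numbers: a 2.3-fold higher number from compound 2 to compound 3 (0.36 log units; beyond the scatter), while a 2.9-fold lower number from compound 1 to compound 3 (0.47 log units; beyond the scatter). Compound 4 `COc1ccc(-c2ccc(N(C[C@@H](N)CC(C)C)C(=O)[C@@H]3C[C@H]3c3ccccc3)cc2)cc1` differs from compound 3 by 4-methoxyphenyl in place of 2-methylphenyl on an aromatic carbon. Within the data shown here, no measured step involves 4-methoxyphenyl; the steps that bear on the change are the other exchanges of the aryl group at this carbon, a 6.7-fold lower number from compound 1 to compound 2 (0.82 log units; beyond the scatter), a 2.9-fold lower number from compound 1 to compound 3 (0.47 log units; beyond the scatter) and a 2.3-fold higher number from compound 2 to compound 3 (0.36 log units; beyond the scatter), each modest. On that basis compound 4 is expected to land close to compound 3. For compound 4 the expected step is a 1.1-fold lower number from compound 3 to compound 4 (0.05 log units; within the scatter). The estimate for compound 4 in this assay is 3000 nM, with a range of 1000 nM to 10000 nM.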

Compound 4, half-maximal effective concentration: 330 nM
The estimate for compound 4 lay 9.1-fold (0.96 log units) above the measured number, outside the stated range (below it).
By their numbers in this assay, from the lowest: compound 4; then compound 2; then compound 3; then compound 1.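

Moving from the earlier aryl groups to 4-methoxyphenyl shows that this position can shift the number much further than the earlier exchanges did: the change gives a 10-fold lower number from compound 3 to compound 4 (1.01 log units; beyond the scatter) and is large, where all earlier steps were modest. The same group also gives a 4.5-fold lower number from compound 2 to compound 4 (0.66 log units; beyond the scatter) and a 30-fold lower number from compound 1 to compound 4 (1.48 log units; beyond the scatter), leaving compound 4 with the lowest number of the four. No evidence at hand explains this result.

Compound 3 and compound 4 differ in both the substituent and its place on the phenyl ring, so the two contributions remain unseparated. A 4-methylphenyl or 2-methoxyphenyl group would separate them, and 4-ethoxyphenyl would test a longer chain on the oxygen.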